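Swapping a Chlorothiophene for a Chlorophenyl Sulfonamide

A few compounds are considered here, and "the series" means these few. Any claim that something is new, unique, unknown or untested is made for them only; others in the source may bear on it.

Two related sulfonamides have so far been tested in an assay on cells for inhibition of HSP60/HSP10 (Homo sapiens), with a stated time of 60 min; on this read-out lower numbers stand for stronger inhibition and higher numbers for weaker inhibition. Going by the values given here, compound 1 `O=S(=O)(Nc1ccc(-c2nc3ccccc3o2)cc1)c1ccc(Cl)s1` gives 31000 nM in this assay, and it stands as the only plain number in the set. Compound 2 `Cc1ccccc1S(=O)(=O)Nc1ccc2oc(-c3ccccc3)nc2c1` gives only a limit of the assay, reported as > 100000 nM in this assay. That limit is described by the limit of > 100000 nM in this assay, at which 1 of the 2 values shown sits, so compound 2 offers no number to compare against.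

Compound 3 `O=S(=O)(Nc1ccc(-c2nc3ccccc3o2)cc1)c1ccc(Cl)cc1` has not yet been measured. It differs from compound 1 in one place: 4-chlorophenyl in place of 5-chlorothiophen-2-yl on a sulfonyl sulfur. Among the compounds with values here, no pair of measured compounds shows a comparable change, so there is no measured step to lean on. The expectation is a step of a 1.1-fold higher number from compound 1 to compound 3 (0.05 log units; within the scatter), which stays within the usual scatter and points in no clear direction. Compound 3 is therefore expected to give about 35000 nM in this assay, with an estimated range from 12000 nM to 100000 nM.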

Compound 3, half-maximal inhibitory concentration: 61000 nM
The estimate for compound 3 lay 1.7-fold (0.24 log units) below the measured number; the range from low to high includes it.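

Replacing the 5-chlorothiophen-2-yl on the sulfonyl sulfur with 4-chlorophenyl gives a 2.0-fold higher number from compound 1 to compound 3 (0.29 log units; within the scatter) in this assay. This position therefore takes a six-membered aromatic ring of carbon only as well as a five-membered aromatic ring with a hetero atom, with no difference that can be told from the scatter. No measurement shown explains this result or gives a property of either group.

On these data alone, it remains open whether a different kind of group on the sulfonyl sulfur, such as an amine, a carboxylic acid or a longer alkyl chain, would move the number beyond the scatter. Compound 2 differs from the other compounds in more than one place, and its value is only a limit of the assay: the limit of > 100000 nM in this assay, at which 1 of the 3 values shown sits.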